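Replacing an aromatic amine with dipropylamino on a shared core

The compounds below may be only part of what the source reports. "The series", "measured", "known", "first", "only" and "open" are said of these compounds alone.

Values measured so far in a functional assay on HeLa cells (Homo sapiens) for inhibition, read by sulforhodamine B assay; a higher number here means a weaker inhibitor, a lower number a stronger inhibitor (two compounds)
- compound 1 `O=C1C=C(Nc2cccc(F)c2)C(=O)c2c1nc1n2[C@H]2OC[C@@H](O)[C@H]2OC1` (6440 nM)
- compound 2 `COc1ccc(NC2=CC(=O)c3nc4n(c3C2=O)[C@H]2OC[C@@H](O)[C@H]2OC4)cc1` (4780 nM)

Compound 2 (4780 nM) stands level with compound 1 (6440 nM), as the gap between these two numbers lies within the scatter. Compound 3 `CCCN(CCC)C1=CC(=O)c2nc3n(c2C1=O)[C@H]1OC[C@@H](O)[C@H]1OC3` keeps the shared core and changes one group, with dipropylamino in place of (4-methoxyphenyl)amino on a double-bonded ring carbon.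

Among the measured compounds shown here, only one measured step bears on this change. It is a 1.3-fold lower number from compound 1 to compound 2 (0.13 log units; within the scatter) and it exchanges one aromatic group on an amine nitrogen for another. For the measured compounds named here, that step says little here, since compound 3 has no aromatic ring in the new group and no measured compound lacks one. The data point in neither direction, so no shift beyond the scatter in this assay can be expected with any confidence, although the uncertainty is wide. The expected change is a 1.2-fold higher number from compound 2 to compound 3 (0.06 log units; within the scatter) as an estimate. For compound 3 the estimated value is 5500 nM with an expected range from 1500 nM to 20000 nM in this assay when measured.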

Compound 3, half-maximal inhibitory concentration: > 16000 nM
Compound 3 gave a limit, no number; the forecaster's own chance of this, stated with the estimate: 10%; middle value at least 2.9-fold (0.46 log units) from the limit.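

In this assay, the double-bonded ring carbon proves less tolerant than the exchange of one aromatic group for another had suggested: putting dipropylamino in place of (4-methoxyphenyl)amino gives an at least 3.3-fold higher number from compound 2 to compound 3 (0.52 log units; beyond the scatter). Putting it in place of (3-fluorophenyl)amino gives an at least 2.4-fold higher number from compound 1 to compound 3 (0.39 log units; beyond the scatter), so the weakening holds against both aromatic amines, while the earlier step between those two stayed within the scatter. Compound 3 is recorded only as a limit of the assay, so the true size of both steps stays unknown: the limit of > 16000 nM in this assay, at which 1 of the 3 values shown sits.

The compounds shown leave open which part of the change matters, as dipropylamino differs from both aromatic amines at once by having no ring and no hydrogen-bond donor, and it also brings two propyl chains onto the nitrogen. A propylamino group, which has a single chain and keeps the amine hydrogen, or an N-methyl-N-phenylamino group, which keeps the aromatic ring but has no amine hydrogen, would help to separate these differences at this position.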